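The source may hold more compounds than are shown below. What is called first, only, known or untested is meant among the compounds shown, and "the series" means these compounds.

In an assay on isolated protein for inhibition of serine protease 1 (Bos taurus) (a higher number here means a weaker inhibitor, a lower number a stronger inhibitor), compound 2, `Cc1c(F)c(Oc2cccc(OC(C)C)c2)nc(Oc2cccc(C(=N)N)c2)c1F`, gives 2900 nM. Among the numbers gathered so far it stands within the scatter of the only other measured compound, compound 1, `Cc1c(F)c(Oc2cccc(C(=N)N)c2)nc(Oc2cccc(C(=O)N3CCCC3)c2)c1F`, which gives 2800 nM; the step of a 1.0-fold higher number from compound 1 to compound 2 (0.02 log units; within the scatter) is flat. Compound 3, `Cc1c(F)c(Oc2cccc(CC(N)=O)c2)nc(Oc2cccc(C(=N)N)c2)c1F`, differs from compound 2 by carbamoylmethyl in place of isopropoxy on an aromatic carbon. Within the data shown here, only that single measured step bears on this change, and it produced no shift beyond the scatter, so no step beyond the scatter is expected from compound 2 to compound 3, no change at the digits printed from compound 2 to compound 3 (within the scatter). Compound 3 is therefore estimated at 2900 nM, with a range from 1200 nM to 6500 nM.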

Compound 3, inhibition constant: > 5000 nM
Compound 3 was reported as a limit (the forecaster's own chance of this, stated with the estimate: 5%); middle value at least 1.7-fold (0.23 log units) away from the limit.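

In this assay compound 3 is reported only as a limit, not as a number: the limit of > 5000 nM in this assay, at which 1 of the 3 values shown sits. The steps read an at least 1.7-fold higher number from compound 2 to compound 3 (0.23 log units; that floor lies within the scatter) and an at least 1.7-fold higher number from compound 1 to compound 3 (0.25 log units; that floor lies within the scatter), so neither floor shows a real loss, but the true size of each could be larger. The position, flat between isopropoxy and (pyrrolidin-1-yl)carbonyl, therefore cannot be called flat for carbamoylmethyl.

As far as these compounds go, how far the true value of compound 3 lies past its limit stays open. So does what an amine or a carboxylic acid on this aromatic carbon would give.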